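A few compounds are considered here, and "the series" means these few. Any claim that something is new, unique, unknown or untested is made for them only; others in the source may bear on it.

Three compounds of the series carry a number in an assay for inhibition of serine/threonine-protein kinase WNK1 (Homo sapiens), read by HTRF, with a stated time of 3 h; a lower number here means a stronger inhibitor, a higher number a weaker inhibitor. Compound 1 `COc1cccc(-c2cc(C(=O)N3CCN(Cc4ccccc4)CC3)c3ccccc3n2)c1` gives 623 nM in this assay. Compound 2 `c1ccc(-c2cccc(-n3cc(CNCC4CCCCC4)c4ccccc43)c2)cc1` gives 2140 nM in this assay. Compound 3 `COc1cccc(-c2cc(-n3cc(CNCC4CCCCC4)c4ccccc43)ccn2)c1` gives 60 nM in this assay, the lowest of the three numbers: compound 1 stands above it by a margin beyond the usual scatter, and compound 2 further above, also beyond the scatter, so compound 3 is the strongest inhibitor of the three measured. Going by the values given here, no pair of measured compounds differs in one place only, so no single step has been worked out between them.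

Compound 4 `COc1cccc(-c2cc(-n3cc(CNCC4CCCCC4)c4ccc(F)cc43)ccn2)c1` has not been measured. It differs from compound 3 by fluoro in place of hydrogen on an aromatic carbon. The entering group is a single fluorine, with no ring, no hydrogen-bond donors or acceptors and no net charge, sitting on an aromatic carbon of a six-membered aromatic ring of carbon only that is part of a fused system of two rings, meta to a fused ring and para to a fused ring. Among the compounds with values here, the series holds no measured step of this kind, so the expectation rests on the small size of the change. The expected step, a 1.2-fold lower number from compound 3 to compound 4 (0.08 log units; within the scatter), is small and not beyond the scatter in either direction. Compound 4 is therefore expected to give 50 nM in this assay, with a range from 20 nM to 150 nM.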

Compound 4, half-maximal inhibitory concentration: 39 nM
For compound 4 the middle estimate is 1.3-fold (0.11 log units) above the measured one; the range from low to high includes it.
By their numbers in this assay, from the lowest: compounds 4 and 3 (each within the scatter of the next); then compound 1; then compound 2.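

Fluoro in place of hydrogen on an aromatic carbon gives a 1.5-fold lower number from compound 3 to compound 4 (0.19 log units; within the scatter) in this assay, and this is the first step in the series that can be read at a single place. The step stays within the scatter, so compound 3 and compound 4 cannot be told apart, and a single fluorine on this aromatic carbon of the fused system, meta to a fused ring and para to a fused ring, leaves the inhibition by the series at the level of compound 3. Nothing on hand accounts for this result, and the size of the step is all that can be stated.

As far as these compounds go, whether this aromatic carbon also accepts something larger or charged, such as chloro, methoxy, an amine or a carboxylic acid, remains open, since one fluorine sets no limit on what fits there. Also open, from the compounds shown here alone, is whether fluoro on the other aromatic carbons of the same ring, or on the methoxy-bearing ring, would give a step of similar size.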